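The source may hold more compounds than are shown below. What is called first, only, known or untested is meant among the compounds shown, and "the series" means these compounds.

Measured so far:
compound 1, `Cc1cc(NC(=O)Cn2nnc(-c3ccccc3)n2)n(C2CCCCC2)n1`, 96 nM
compound 2, `Cc1cc(NC(=O)Cn2nnc(-c3ccccc3)n2)n(C2CCC(C)(C)CC2)n1`, > 221 nM
compound 3, `Cc1cc(NC(=O)Cn2nnc(-c3ccccc3)n2)n(C(C)C)n1`, 556 nM

In an assay on HEK293 cells for activation of Kir3.1/Kir3.2 (Homo sapiens), read by thallium flux (on this read-out lower numbers stand for an effect already at smaller amounts and higher numbers for an effect only at larger amounts of compound), compound 1 gives the lowest of the two numbers; its nearest neighbour is compound 3, with a 5.8-fold higher number from compound 1 to compound 3 (0.76 log units; beyond the scatter). For compound 2 this assay gives only a limit, (the limit of > 221 nM in this assay, at which 1 of the 3 values shown sits). Compound 4, `O=C(Cn1nnc(-c2ccccc2)n1)Nc1cc(C2(C(F)(F)F)CC2)nn1C1CCCCC1`, differs from compound 1 by 1-(trifluoromethyl)cyclopropyl in place of methyl on an aromatic carbon. The measured steps, an at least 2.3-fold higher number from compound 1 to compound 2 (0.36 log units; beyond the scatter) and a 5.8-fold higher number from compound 1 to compound 3 (0.76 log units; beyond the scatter), all concern the group on the aromatic nitrogen and leave the aromatic carbon untouched, so none of them bears directly on this change; the expectation rests on the size of the entering group alone and is therefore uncertain. Compound 4 is expected to give about 200 nM in this assay, between 60 nM and 700 nM. This expectation amounts to a 2.1-fold higher number from compound 1 to compound 4 (0.32 log units; beyond the scatter).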

Compound 4, half-maximal effective concentration: "not active" (no number reported)
No number was reported for compound 4, so the estimate cannot be set against anything.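

Compound 4 is reported as not active, without a number, so no step from compound 1 to compound 4 can be read, and nothing shown accounts for this result. The compounds shown leave open how any other group on that aromatic carbon would behave.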